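A few compounds are considered here, and "the series" means these few. Any claim that something is new, unique, unknown or untested is made for them only; others in the source may bear on it.

Of the compounds shown here, three that share one core have been tested in a functional assay on MT4 cells (Homo sapiens); a higher number here means that more compound is tolerated, a lower number that less compound is tolerated. In this assay compound 1 `Cc1cn([C@@H]2O[C@H](CO[Si](C)(C)C(C)(C)C)[C@@]3(OS(=O)(=O)C=C3NC(=O)c3ccccc3)[C@H]2O[Si](C)(C)C(C)(C)C)c(=O)n(C)c1=O` gives 4900 nM. In this assay compound 2 `COC(=O)C(=O)CNC1=CS(=O)(=O)O[C@@]12[C@@H](CO[Si](C)(C)C(C)(C)C)O[C@@H](n1cc(C)c(=O)n(C)c1=O)[C@@H]2O[Si](C)(C)C(C)(C)C` gives 10300 nM. In this assay compound 3 `Cc1cn([C@@H]2O[C@H](CO[Si](C)(C)C(C)(C)C)[C@@]3(OS(=O)(=O)C=C3NC(N)=O)[C@H]2O[Si](C)(C)C(C)(C)C)c(=O)n(C)c1=O` gives 3700 nM. Compound 3 has the lowest of the three numbers, yet its gap to compound 1 is within the scatter, so the two cannot be told apart; only compound 2 sits clearly apart, as a 2.8-fold lower number from compound 2 to compound 3 (0.44 log units; beyond the scatter) shows. The remaining steps are a 2.1-fold higher number from compound 1 to compound 2 (0.32 log units; beyond the scatter) and a 1.3-fold lower number from compound 1 to compound 3 (0.12 log units; within the scatter).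

Compound 4 `Cc1cn([C@@H]2O[C@H](CO[Si](C)(C)C(C)(C)C)[C@@]3(OS(=O)(=O)C=C3NCCC(=O)O)[C@H]2O[Si](C)(C)C(C)(C)C)c(=O)n(C)c1=O` has not yet been measured. It differs from compound 3 in one place: 2-carboxyethyl in place of carbamoyl on an amine nitrogen. Every measured step exchanges the group on that same amine nitrogen, and none of them shifted the number by more than a modest amount, so a further exchange at that place is expected to do little in this assay as well. Within the data shown here, no measured step involves the 2-carboxyethyl group itself, so the direction cannot be read from the data. For compound 4 a step of about a 1.4-fold higher number from compound 3 to compound 4 (0.13 log units; within the scatter) is expected, giving an estimate near 5000 nM with a range from 2000 nM to 13000 nM.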

Compound 4, half-maximal cytotoxic concentration: 11500 nM
Beside the measured number, compound 4's estimate is 2.3-fold (0.36 log units) below it; the range from low to high includes it.
By their numbers in this assay, from the lowest: compounds 3 and 1 (each within the scatter of the next); then compounds 2 and 4 (each within the scatter of the next).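

In this assay the exchange of carbamoyl for 2-carboxyethyl on the amine nitrogen gives a 3.1-fold higher number from compound 3 to compound 4 (0.49 log units; beyond the scatter) and is therefore a real but modest change, and the exchange of benzoyl for the same group gives a 2.3-fold higher number from compound 1 to compound 4 (0.37 log units; beyond the scatter) in the same direction. The comparison with the other compound that has a saturated chain carbon on this nitrogen shows a 1.1-fold higher number from compound 2 to compound 4 (0.05 log units; within the scatter) and so no separation, which means the four compounds now fall into two groups: those with a saturated chain carbon on the nitrogen have the higher numbers, those with a carbonyl there the lower numbers, and no listed compound goes against this. No measurement is available that would explain this split.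

Going by these compounds, it remains open whether a plain propyl chain on the same nitrogen would join the higher group, which would separate the contribution of the chain from that of the carboxylic acid at its end. On these data alone, how a longer chain, or a chain ending in an amine, would behave at this place is equally open.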